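The compounds below may be only part of what the source reports. "The series", "measured", "known", "first", "only" and "open" are said of these compounds alone.

Of the compounds shown here, three built on one shared core have been measured in an ADME assay on NIH3T3 cells (Mus musculus) for cytotoxicity, read by MTT assay, with a stated time of 24 h; a lower number here means a stronger inhibitor, a higher number a weaker inhibitor. Compound 1 `O=C(CSc1nnc(-c2ccncc2)o1)N/N=C/c1ccc(O)cc1` gives 158000 nM in this assay. Compound 2 `Cc1ccc(/C=N/NC(=O)CSc2nnc(-c3ccncc3)o2)cc1` gives 185000 nM, and compound 3 `O=C(CSc1nnc(-c2ccncc2)o1)N/N=C/c1ccccc1F` gives 142000 nM. Among these three numbers compound 1 stands second highest; its nearest neighbour is compound 3, with a 1.1-fold lower number from compound 1 to compound 3 (0.05 log units; within the scatter), and its furthest is compound 2, with a 1.2-fold higher number from compound 1 to compound 2 (0.07 log units; within the scatter). The remaining pair shows a 1.3-fold lower number from compound 2 to compound 3 (0.11 log units; within the scatter). All three steps lie within the usual scatter, so no ordering among the measured compounds can be claimed.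

Compound 4 `O=C(CSc1nnc(-c2ccncc2)o1)N/N=C/c1ccc(O)c(O)c1` is not yet measured. It differs from compound 1 in one place: hydroxy in place of hydrogen on an aromatic carbon. Seen one bond further out, this takes 4-hydroxyphenyl to 3,4-dihydroxyphenyl.

Each step already seen swaps the group on that aromatic ring, and none of them moved the number beyond the scatter: a 1.2-fold higher number from compound 1 to compound 2 (0.07 log units; within the scatter) and a 1.1-fold lower number from compound 1 to compound 3 (0.05 log units; within the scatter) in particular show how little such a change has mattered so far. On that evidence compound 4 is expected to change little, with an expected step of a 1.1-fold lower number from compound 1 to compound 4 (0.02 log units; within the scatter). Compound 4 is therefore estimated at 150000 nM in this assay, within a range from 75000 nM to 300000 nM.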

Compound 4, half-maximal inhibitory concentration: 154000 nM
Compound 4: middle estimate off by 1.0-fold (0.01 log units), on the low side; measured number inside the range.
By their numbers in this assay, from the lowest: compounds 3, 4, 1 and 2 (each within the scatter of the next).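

Among the compounds shown here, compound 4 is the first compound here in which a group is added to the aromatic ring rather than swapped for another, with the new hydroxy placed ortho to the existing hydroxy group, and in this assay this gives a 1.0-fold lower number from compound 1 to compound 4 (0.01 log units; within the scatter). Comparing the whole ring substituent with those of the other compounds gives the same picture, with a 1.1-fold higher number from compound 3 to compound 4 (0.04 log units; within the scatter) and a 1.2-fold lower number from compound 2 to compound 4 (0.08 log units; within the scatter), so 3,4-dihydroxyphenyl cannot be told apart from 4-hydroxyphenyl, 4-methylphenyl or 2-fluorophenyl in this assay, and a second hydroxy group on this ring brings no readable change. No measurement available here offers an explanation for this flat result.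

On these data alone, the ring in these four compounds carries only hydroxy, methyl or fluoro groups, so it remains open whether an amine, a carboxylic acid or a longer chain in the same place would move the number beyond the scatter. As far as these compounds go, what a change elsewhere in the shared core would do also remains open, as all four compounds keep that part the same.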